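The source may report more compounds than this note shows. Statements on the series, on what has been measured and on what is new or still open speak of the compounds shown alone.

Measured so far:
- compound 1 `Cc1ccc(C(=O)Nc2ccc(O)c3c(=O)cc(-c4ccccc4Cl)oc23)cc1`: 10000 nM
- compound 2 `Cc1ccc(C(=O)Nc2c(O)cc(O)c3c(=O)cc(-c4ccccc4Cl)oc23)cc1`: 9700 nM
- compound 3 `CC(C)C[C@H](NC(=O)OC(C)(C)C)C(=O)Nc1ccc(O)c2c(=O)cc(-c3ccccc3Cl)oc12`: 4000 nM

In a functional assay on MCF7 cells (Homo sapiens) for antiproliferative activity (a lower number here means a stronger inhibitor, a higher number a weaker inhibitor), compound 1 gives 10000 nM. It sits level with compound 2 within the scatter, while compound 3 shows a lower number, beyond the scatter.

Compound 4 `CCC(C)OC(=O)Nc1ccc(O)c2c(=O)cc(-c3ccccc3Cl)oc12` is not yet measured. It carries sec-butoxy in place of 4-methylphenyl on a carbonyl carbon whose other neighbour is an amide-type nitrogen: sec-butoxy in place of 4-methylphenyl on a carbonyl carbon.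

Among the measured compounds shown here, the one measured step, a 1.0-fold lower number from compound 1 to compound 2 (0.01 log units; within the scatter), is a different change, hydroxy in place of hydrogen on an aromatic carbon, so it says little about this one. The closest guide is compound 3, which also lacks the 4-methylphenyl and reads 4000 nM. That single value suggests a modest move towards a lower number, though the data hold no direct match for the change.

The expected step is a 1.7-fold lower number from compound 1 to compound 4 (0.22 log units; within the scatter), which would not clearly exceed the scatter. For compound 4 the estimated value is 6000 nM, with an expected range of 2500 nM to 14000 nM.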

Compound 4, half-maximal inhibitory concentration: 30000 nM
Estimate against measurement, compound 4: 5.0-fold (0.70 log units) below; the whole stated range lies below it.
By their numbers in this assay, from the lowest: compound 3; then compounds 2 and 1 (each within the scatter of the next); then compound 4.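

In this assay, among the compounds shown here, the substituent on the carbonyl carbon whose other neighbour is the amide-type nitrogen affects the read-out: the change to sec-butoxy gives a 3.0-fold higher number from compound 1 to compound 4 (0.48 log units; beyond the scatter) and is the first step to lie beyond the scatter, whereas a 1.0-fold lower number from compound 1 to compound 2 (0.01 log units; within the scatter) is a different change and stays within it. At this place, swapping 4-methylphenyl for sec-butoxy therefore moves towards weaker inhibition, while the change removes the aromatic ring and adds one hydrogen-bond acceptor. No measured evidence bears on the reason for this rise.

For the compounds shown here, the single step leaves open whether the loss of the aromatic ring or the arrival of the oxygen link accounts for the shift, as both change together. A benzyloxy group or an n-butyl chain on the same carbonyl carbon would separate the two.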